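A few compounds are considered here, and "the series" means these few. Any claim that something is new, unique, unknown or untested is made for them only; others in the source may bear on it.

Measured in a functional assay on MCF7 cells (Homo sapiens) for cytotoxicity, read by sulforhodamine B assay, with a stated time of 24 h; on this read-out lower numbers stand for stronger inhibition and higher numbers for weaker inhibition:
- compound 1 `O=C1Nc2ccc(S(=O)(=O)N3CCOCC3)cc2/C1=N/c1ccc(O)cc1`: 52700 nM
- compound 2 `CC(=O)N/N=C1\C(=O)Nc2ccc(S(=O)(=O)N3CCOCC3)cc21`: 56000 nM

Only these two compounds have been measured, and their values lie within the scatter of each other, so compound 2 stands level with compound 1 and neither can be ranked. The next compound, compound 3 `CC(=O)c1cccc(/N=C2\C(=O)Nc3ccc(S(=O)(=O)N4CCOCC4)cc32)c1`, has 3-acetylphenyl in place of acetamido on a double-bonded nitrogen.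

For the measured compounds named here, one measured step bears on this change. It involves the same double-bonded nitrogen, where acetamido took the place of 4-hydroxyphenyl, and it came to a 1.1-fold higher number from compound 1 to compound 2 (0.03 log units; within the scatter). Compound 3 again carries a substituted phenyl group at that nitrogen, although 3-acetylphenyl itself has not been measured on this core, and a single step offers only limited guidance. Exchanging these groups has so far left the number in this assay essentially unmoved, so no shift beyond the scatter is expected. The estimated change is a 1.1-fold lower number from compound 2 to compound 3 (0.05 log units; within the scatter). Compound 3 is expected at 50000 nM, with an estimated range from 18000 nM to 110000 nM.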

Compound 3, half-maximal inhibitory concentration: 39200 nM
Estimate against measurement, compound 3: 1.3-fold (0.11 log units) above; the measured number falls inside the stated range.
By their numbers in this assay, from the lowest: compounds 3, 1 and 2 (each within the scatter of the next).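

At the double-bonded nitrogen of the shared core, this assay now covers three different groups: 3-acetylphenyl in place of acetamido gives a 1.4-fold lower number from compound 2 to compound 3 (0.15 log units; within the scatter), and the same group in place of 4-hydroxyphenyl gives a 1.3-fold lower number from compound 1 to compound 3 (0.13 log units; within the scatter). The second step shows that a phenyl group with a different substituent leaves compound 3 level with compound 1, and the first shows that compound 3 also stands level with compound 2, even with 9 heavy atoms entering for 4 and one six-membered aromatic ring entering where acetamido had no ring. Nothing available here accounts for these three groups standing level.

The three groups leave open whether any group at this nitrogen can move the number beyond the scatter, for instance a phenyl ring carrying a carboxylic acid or an amine, or a longer chain ending in an amine. Since the rest of the core is the same in compounds 1, 2 and 3, they also leave open how the number responds to a replacement anywhere else on it.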